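Adding a Third Methoxy Group to a Chalcone Acrylamide

A few compounds are considered here, and "the series" means these few. Any claim that something is new, unique, unknown or untested is made for them only; others in the source may bear on it.

The series starts from compound 1 `C=C(Br)C(=O)Nc1ccc(C(=O)/C=C/c2ccccc2)cc1`, which in a functional assay on MOLT-4 cells (Homo sapiens) for antiproliferative activity, with a stated time of 48 h (on this read-out lower numbers stand for stronger inhibition and higher numbers for weaker inhibition), gives 500 nM. Compound 2 `C=C(Br)C(=O)Nc1ccc(C(=O)/C=C/c2cccc(OC)c2)cc1` differs from it by methoxy in place of hydrogen on an aromatic carbon, placed on an aromatic carbon of a six-membered aromatic ring of carbon only, meta to a large group; in this assay compound 2 gives 1100 nM, so that the step of a 2.2-fold higher number from compound 1 to compound 2 (0.34 log units; beyond the scatter) is a modest loss that lies beyond the scatter. Compound 3 `C=C(Br)C(=O)Nc1ccc(C(=O)/C=C/c2ccc(OC)cc2OC)cc1` carries two methoxy groups on that ring; the difference between its core and the core of compound 1 is not broken down here. In this assay compound 3 gives 1500 nM, which is within the scatter of compound 2 and beyond it relative to compound 1.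

Compound 4 `C=C(Br)C(=O)Nc1ccc(C(=O)/C=C/c2ccc(OC)c(OC)c2OC)cc1` has not yet been tested. Relative to compound 3 it shows (methoxy in place of hydrogen on an aromatic carbon), and here the new group sits ortho to two methoxy groups and meta to a large group, so this is the same kind of change as that from compound 1 to compound 2 rather than the same change. Because the earlier step of a 2.2-fold higher number from compound 1 to compound 2 (0.34 log units; beyond the scatter) was a modest loss, the step of a 1.5-fold higher number from compound 3 to compound 4 (0.19 log units; within the scatter) is expected to be of a similar modest size. Compound 4 is therefore estimated to give 2300 nM in this assay, with a likely range from 1000 nM to 5500 nM.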

Compound 4, half-maximal inhibitory concentration: 680 nM
Compound 4: the middle estimate sits 3.4-fold (0.53 log units) above what was measured, and the stated range ends above it.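

In this assay, methoxy in place of hydrogen on an aromatic carbon gives a 2.2-fold lower number from compound 3 to compound 4 (0.34 log units; beyond the scatter), whereas the same kind of change earlier gave a 2.2-fold higher number from compound 1 to compound 2 (0.34 log units; beyond the scatter). The two steps are of modest size but run in opposite directions, and the gap between them is larger than repeated measurements would explain: the same change on two cores in this assay, a 2.2-fold higher number (0.34 log units; beyond the scatter) from compound 1 to compound 2 and a 2.2-fold lower number (0.34 log units; beyond the scatter) from compound 3 to compound 4, 4.9-fold (0.69 log units) apart, beyond the scatter of two such steps. This shows that, in this series, the effect of this change cannot be carried from the core of compound 1 to the core of compound 3 with either its size or its direction intact, but it does not show what sets the difference, since the cores differ and the new group stands ortho to two methoxy groups only in compound 4, and each step rests on a single pair of compounds.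

The compounds shown leave open whether the same reversal would appear with a hydroxy group, an amine or a longer chain such as ethoxy in place of the new methoxy group. They also leave open whether a methoxy group added at that same place on the core of compound 1 would raise or lower the number.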